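From 2-bromophenyl to cyclohexyl on a sulfur-linked chain

The compounds below may be only part of what the source reports. "The series", "measured", "known", "first", "only" and "open" are said of these compounds alone.

Of the compounds shown here, three with a shared core have been tested in a toxicity assay on GES1 cells (Homo sapiens) for inhibition, read by MTT assay, with a stated time of 72 h; on this read-out lower numbers stand for stronger inhibition and higher numbers for weaker inhibition. Compound 1 `C[C@@H]1CCN(c2cc(-c3ccccc3)nc3ncnn23)C[C@@H]1N(C)c1ncnc2[nH]ccc12` is reported only as a limit, > 100000 nM. Compound 2 `Cc1cc(N2CC[C@@H](C)[C@@H](N(C)c3ncnc4[nH]ccc34)C2)n2nc(SCc3ccccc3Br)nc2n1` is likewise reported only as a limit, > 100000 nM. Compound 3 `Cc1nc2nc(SCc3ccc(Cl)cc3)nn2c(N2CC[C@@H](C)[C@@H](N(C)c3ncnc4[nH]ccc34)C2)c1C` gives a number, 99200 nM. Compound 2 thus stands at the limit of > 100000 nM in this assay, at which 2 of the 3 values shown sit, and no exact value is known for it.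

Compound 4 `Cc1cc(N2CC[C@@H](C)[C@@H](N(C)c3ncnc4[nH]ccc34)C2)n2nc(SCC3CCCCC3)nc2n1` has cyclohexyl in place of 2-bromophenyl on a saturated chain carbon bound to a sulfur, which turns 2-bromobenzyl into cyclohexylmethyl: cyclohexyl in place of 2-bromophenyl on a saturated chain carbon bound to a sulfur. Going by the values given here, no measured pair in this set isolates a change of this kind, so the expectation rests on the three results alone. Among the compounds with values here, since compound 3 at 99200 nM is the only measured number, no large shift is expected in this assay. The expected step of a number no higher from compound 2 to compound 4 (the limit leaves the size open) stays within the usual scatter, in neither direction, and the result may again be only a limit. Compound 4 is estimated at 100000 nM, with an expected range from 50000 nM to 200000 nM.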

Compound 4, half-maximal inhibitory concentration: 98200 nM
Compound 4: middle estimate off by 1.0-fold (0.01 log units), on the high side, within the range that was stated.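

In this assay, cyclohexyl in place of 2-bromophenyl on a saturated chain carbon bound to a sulfur gives an at least 1.0-fold lower number from compound 2 to compound 4 (0.00 log units; that floor lies within the scatter), so the data show no shift when a non-aromatic ring of carbon only takes the place of the brominated aromatic ring. Going by these compounds alone, compound 4 gives 98200 nM, which puts a measured number on this sulfur-linked position for the first time. The value of compound 2 remains a limit, so the true size of the step cannot be read: the limit of > 100000 nM in this assay, at which 2 of the 4 values shown sit.

Still open, from the compounds shown here alone, is whether a different group on the sulfur-linked chain, such as an amine, a carboxylic acid or a longer chain, would move the number in this assay. Also open, going by these compounds, is how unsubstituted benzyl would read, which would separate the loss of the bromine from the loss of the aromatic ring.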